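Replacing 3-fluorophenyl with 4-chlorophenyl on the shared core

The source may hold more compounds than are shown below. What is called first, only, known or untested is meant among the compounds shown, and "the series" means these compounds.

Measured so far:
Compound 1, `O=S(=O)(c1ccc(F)c(F)c1)c1cnc2cc(F)ccc2c1-c1ccc(Cl)cc1`: 1.41 mL/min
Compound 2, `O=S(=O)(c1cc(Cl)cc(Cl)c1)c1cnc2cc(F)ccc2c1-c1cccc(F)c1`: 1.53 mL/min

Both numbers come from an ADME assay on microsomes from liver (Rattus norvegicus) for metabolic stability, tested at 2.5 uM; a lower number here means slower removal, a higher number faster removal of the compound. Compound 2 stands with the highest of the two numbers in this assay, and its nearest neighbour is compound 1, whose number lies within the scatter of that of compound 2, so the two cannot be told apart on these data.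

Compound 3, `O=S(=O)(c1cc(Cl)cc(Cl)c1)c1cnc2cc(F)ccc2c1-c1ccc(Cl)cc1`, has not yet been measured in this assay. Compound 3 differs from compound 2 in one place: 4-chlorophenyl in place of 3-fluorophenyl on an aromatic carbon. Compound 1 already carries the 4-chlorophenyl group and gives 1.41 mL/min, close to the number of compound 2, so the step is expected to stay within the scatter, in no clear direction. The expected step is a 1.0-fold higher number from compound 2 to compound 3 (0.01 log units; within the scatter). Compound 3 is therefore estimated at 1.55 mL/min, with a range from 0.9 mL/min to 2.7 mL/min.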

Compound 3, intrinsic clearance in a liver preparation (reported as CLH), per the amount of preparation that the assay uses: 0.77 mL/min
Compound 3: the middle estimate sits 2.0-fold (0.30 log units) above what was measured; the measured number lies below the stated range.
By their numbers in this assay, from the lowest: compounds 3, 1 and 2 (each within the scatter of the next).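

In this assay, for the compounds shown here, 4-chlorophenyl in place of 3-fluorophenyl, at the carbon opposite the ring nitrogen, gives a 2.0-fold lower number from compound 2 to compound 3 (0.30 log units; within the scatter); this is the first reading of the change in one place, and it stays within the scatter, so no effect of this change can be told from repeat noise. On the sulfonyl sulfur, 3,5-dichlorophenyl in place of 3,4-difluorophenyl gives a 1.8-fold lower number from compound 1 to compound 3 (0.26 log units; within the scatter), also within the scatter, so neither position yet shows a clear effect in these three compounds. Nothing in the data gives a cause for either step.

The step from 3-fluorophenyl to 4-chlorophenyl alters both the halogen and its place on the ring, and the compounds shown do not separate the two. On these data alone, whether a methoxy group or an amine on that ring would give a step beyond the scatter also stays open.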